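This account rests on a few compounds, and the source may have more. Where it says the series, first, only, none or still open, it means among the compounds named here.

Measured in an ADME assay on BCBL1 cells (Homo sapiens) for cytotoxicity, with a stated time of 7 days; a lower number here means that less compound is tolerated, a higher number that more compound is tolerated:
- Compound 1 `CCCNc1nc(N)nc2c1ncn2/C=C1/CC1(CO)CO`: > 20000 nM (a limit)
- Compound 2 `Nc1nc(NC2CCCC2)c2ncn(/C=C3/CC3(CO)CO)c2n1`: 71700 nM
- Compound 3 `CSc1nc(N)nc2c1ncn2/C=C1/CC1(CO)CO`: > 20000 nM (a limit)

Compound 3 has no exact number in this assay, only a limit, and its place on the scale is therefore open. The same limit recurs across this small set: the limit of > 20000 nM in this assay, at which 2 of the 3 values shown sit. Compound 4 `CC(C)CNc1nc(N)nc2c1ncn2/C=C1/CC1(CO)CO` carries isobutylamino in place of methylsulfanyl on an aromatic carbon.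

The measured steps closest to this change are a step that the two limits leave unreadable from compound 1 to compound 3 and a step that the limit leaves unreadable from compound 2 to compound 3, along with a step that the limit leaves unreadable from compound 1 to compound 2. None of them has a readable size, so none can be carried over as a number. Compound 1, with propylamino, is the nearest relative, and its > 20000 nM is also a limit. Among the compounds with values here, compound 2 supplies the only exact number, 71700 nM.

No clear move in either direction is therefore expected, and the assay may again report only a limit. The expected change is a step that the limit leaves unreadable from compound 3 to compound 4. For compound 4 the estimate is 40000 nM, with an expected range of 20000 nM to 90000 nM.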

Compound 4, half-maximal cytotoxic concentration: > 20000 nM
Compound 4 ended at the assay's limit (the forecaster's own chance of this, stated with the estimate: 65%); the middle value does not contradict the limit.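

No new step can be read from compound 4: in this assay compound 4 gives > 20000 nM, which is a limit, so its comparisons with compound 1, compound 2 and compound 3 stay unreadable. The compounds shown leave open how much the group on the aromatic carbon changes the tolerated concentration, as most values sit at one limit: the limit of > 20000 nM in this assay, at which 3 of the 4 values shown sit.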